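Closing the Open Amine Chain into an Azetidine Ring

The compounds below may be only part of what the source reports. "The series", "measured", "known", "first", "only" and "open" are said of these compounds alone.

Measured so far:
- compound 1 `C#CCN(Cc1ccc(OCc2cccc(F)c2)cc1)[C@@H](C)C(N)=O`, which in an assay on Sf9 cells for inhibition of Amine oxidase [flavin-containing] A (Homo sapiens), with stated times of 15 min and 60 min (on this read-out higher numbers stand for weaker inhibition and lower numbers for stronger inhibition), gives 7790 nM
- compound 2 `Cc1cc(OCc2cccc(F)c2)ccc1CN[C@@H](C)C(N)=O`, for which this assay reports only a limit, > 10000 nM
- compound 3 `CC1(C)C[C@@H](C(N)=O)N(Cc2ccc(OCc3cccc(F)c3)cc2)C1`, which in this assay gives 17500 nM

All three compounds share a benzyl ether core carrying a fluorobenzyl group, and all three sit at the weak end of the read-out. For the measured compounds named here, compound 2 is the one whose value is not a number at all: the assay reports a limit for compound 2, so only its lower bound is known (the limit of > 10000 nM in this assay, at which 1 of the 3 values shown sits). On the numbers shown, therefore, compound 2 stands at or beyond the weakest point that can be resolved.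

Compound 4 `Cc1cc(OCc2cccc(F)c2)ccc1CN1CC[C@H]1C(N)=O` has not yet been measured. It differs from compound 2 in a single place: 2-carbamoylazetidin-1-yl in place of (1-carbamoylethyl)amino on a saturated chain carbon bound to an aromatic carbon. The open chain of compound 2 is thus tied back onto the nitrogen to form a small ring, while the carboxamide stays in place.

Because compound 3, which also carries a ring-closed carboxamide, gives 17500 nM, a ring of this kind does not appear to rescue inhibition in this series. Compound 4 is therefore expected to remain weak, with a step from compound 2 of a step that the limit leaves unreadable from compound 2 to compound 4 that is not beyond the usual scatter. The estimate for compound 4 is 15000 nM, within a range from 4000 nM to 60000 nM, and it is expected that the assay may again report only a limit.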

Compound 4, half-maximal inhibitory concentration: 8650 nM
Estimate against measurement, compound 4: 1.7-fold (0.24 log units) above, and the stated range covers the measured number.
By their numbers in this assay, from the lowest: compounds 1 and 4 (each within the scatter of the next); then compound 3.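

In this assay, for the compounds shown here, compound 4 gives 8650 nM, the first true number for the core of compound 2. Compound 2 itself carries only a limit, > 10000 nM. Putting 2-carbamoylazetidin-1-yl in place of (1-carbamoylethyl)amino, on a saturated chain carbon bound to an aromatic carbon, gives an at least 1.1-fold lower number from compound 2 to compound 4 (0.06 log units; that floor lies within the scatter), so this change can be tolerated with a readable result, but no gain beyond the scatter can be claimed, and the real size of the step stays unknown because one end of it is only a limit: the limit of > 10000 nM in this assay, at which 1 of the 4 values shown sits.

As far as these compounds go, what remains open is whether the ring itself changes inhibition at all, since a true number for the open chain of compound 2 is still missing. Also open, from the compounds shown here alone, is how much the carboxamide on the four-membered ring matters, for example whether a carboxylic acid or a nitrile in its place would give a lower number or a higher one in this assay.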